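The source may hold more compounds than are shown below. What is called first, only, known or untested is meant among the compounds shown, and "the series" means these compounds.

In an assay on microsomes from intestine for inhibition of acyl-CoA:cholesterol acyltransferase (Oryctolagus cuniculus) (on this read-out lower numbers stand for stronger inhibition and higher numbers for weaker inhibition), compound 2 `CCCCCCCCCCCCOC(=O)NC(=O)Oc1c(C(C)C)cccc1C(C)C` gives 21 nM, the lowest number of the two measured, while compound 1 `CCCCCCCCOC(=O)NC(=O)Oc1c(C(C)C)cccc1C(C)C` gives 250 nM. Compound 3 `CCCCCCCCCCCCCOC(=O)NC(=O)Oc1c(C(C)C)cccc1C(C)C` differs from compound 2 by methyl in place of hydrogen on a saturated chain carbon, ten or more bonds along the chain from an oxygen next to a carbonyl group. Among the compounds with values here, the only measured step bearing on this is a 12-fold lower number from compound 1 to compound 2 (1.08 log units; beyond the scatter), which came from a butyl addition. A single added methyl is expected to carry much less than that, so a small further lowering or a step within the scatter is expected, a 1.4-fold lower number from compound 2 to compound 3 (0.15 log units; within the scatter). Compound 3 is therefore estimated at 15 nM, within 6 nM to 45 nM.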

Compound 3, half-maximal inhibitory concentration: 9 nM
Compound 3: middle estimate off by 1.7-fold (0.22 log units), on the high side; the range from low to high includes it.
By their numbers in this assay, from the lowest: compound 3; then compound 2; then compound 1.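

In this assay a single added methyl at this far end of the chain still counts: a 2.3-fold lower number from compound 2 to compound 3 (0.37 log units; beyond the scatter), beyond the scatter, so the lowering seen with the butyl addition has not levelled off at compound 2. Over the whole series the change amounts to a 28-fold lower number from compound 1 to compound 3 (1.44 log units; beyond the scatter), and across these three compounds the number falls as the chain grows, with none going against this. Nothing measured here bears on the reason for this trend.

Going by these compounds, whether a still longer chain lowers the number further or reverses the trend remains open. So does the effect of a branched chain, or of an amine or a carboxylic acid on the chain.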